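Sulfonyl substituent exchange: phenylcyclopropyl for difluoro(phenyl)methyl

The compounds below may be only part of what the source reports. "The series", "measured", "known", "first", "only" and "open" are said of these compounds alone.

The shared core is carried by compound 1 `N#Cc1cc2c(nc1N1CCC(C(=O)NS(=O)(=O)Cc3ccc(Cl)cc3)CC1)COC2=O` and compound 2 `Cc1ccc(CS(=O)(=O)NC(=O)C2CCN(c3nc4c(cc3C#N)C(=O)OC4)CC2)cc1`. In a functional assay (Platelet, plasma) for inhibition, with Homo sapiens as the target (on this read-out higher numbers stand for weaker inhibition and lower numbers for stronger inhibition), compound 1 gives 4420 nM, and in this assay compound 2 gives 4280 nM. Within the data shown here, the single measured step, a 1.0-fold lower number from compound 1 to compound 2 (0.01 log units; within the scatter), shows a change on an aromatic carbon leaving the read-out unchanged within the scatter. Compound 3 `N#Cc1cc2c(nc1N1CCC(C(=O)NS(=O)(=O)C(F)(F)c3ccccc3)CC1)COC2=O` carries difluoro(phenyl)methyl on the sulfonyl sulfur; in this assay compound 3 gives "not determined" (no result reported), so compound 3 stands without a number of its own, and its place can only be guessed from the two measured compounds, which sit close together.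

Compound 4 `N#Cc1cc2c(nc1N1CCC(C(=O)NS(=O)(=O)C3(c4ccccc4)CC3)CC1)COC2=O` differs from compound 3 by 1-phenylcyclopropyl in place of difluoro(phenyl)methyl on a sulfonyl sulfur. Among the measured compounds shown here, no measured step bears on an exchange at the sulfonyl sulfur; the one step that exists, a 1.0-fold lower number from compound 1 to compound 2 (0.01 log units; within the scatter), concerns another place and was within the scatter, so it offers no direction. Compound 4 is therefore expected to fall in the same region as compounds 1 and 2, with wide uncertainty.

For compound 4 the estimate in this assay is 4500 nM, expected to lie between 1200 nM and 17000 nM.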

Compound 4, half-maximal inhibitory concentration: 4100 nM
The estimate for compound 4 lay 1.1-fold (0.04 log units) above the measured number, and the stated range covers the measured number.
By their numbers in this assay, from the lowest: compounds 4, 2 and 1 (each within the scatter of the next).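

In this assay the sulfonyl sulfur now has measured exchanges: 1-phenylcyclopropyl in place of 4-methylbenzyl gives a 1.0-fold lower number from compound 2 to compound 4 (0.02 log units; within the scatter) and 1-phenylcyclopropyl in place of 4-chlorobenzyl gives a 1.1-fold lower number from compound 1 to compound 4 (0.03 log units; within the scatter) for this series. The earlier step concerned only an aromatic carbon, whereas these two show that replacing the whole substituted benzyl group on the sulfonyl sulfur with a group holding a three-membered ring also leaves the read-out within the scatter across compound 1, compound 2 and compound 4. No supporting measurement accounts for this flat result.

From the compounds shown here alone, whether any group on the sulfonyl sulfur can move the read-out beyond the scatter remains open. The compounds shown leave untested there a substituent carrying an amine or a carboxylic acid, or a longer alkyl chain.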